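The source may report more compounds than this note shows. Statements on the series, on what has been measured and on what is new or still open speak of the compounds shown alone.

Compound 1 `CCCCOc1ccccc1-c1ncc(C(=O)OCC)c(=O)[nH]1`: 0.5 mg/kg
Compound 2 `CCOC(=O)c1cnc(-c2ccccc2OC(C)CC)[nH]c1=O`: 0.5 mg/kg
Compound 3 `C=CCOc1ccccc1-c1ncc(C(=O)OCC)c(=O)[nH]1`: 0.5 mg/kg

In a functional assay on the whole organism (strain Sprague-Dawley) for inhibition, with Rattus norvegicus as the target, with a stated time of 10 min (a higher number here means that more compound is needed for the effect, a lower number that less compound is needed), compound 3 stands level with compound 1 and compound 2 at the digits measured. The next compound is compound 4 `CCOC(=O)c1cnc(-c2ccccc2SCC)[nH]c1=O`, and the change is ethylsulfanyl in place of allyloxy on an aromatic carbon, ortho to a large group.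

Among the measured compounds shown here, three measured steps bear on this place, all of them changes in the chain on the oxygen: no change at the digits printed from compound 1 to compound 2 (within the scatter), no change at the digits printed from compound 1 to compound 3 (within the scatter) and no change at the digits printed from compound 2 to compound 3 (within the scatter). None of the three was large, so this position has tolerated each chain tried so far. For the measured compounds named here, none of them replaces the oxygen with sulfur, however, and no measured compound carries sulfur here, so the support is only indirect.

No step beyond the scatter is therefore expected, though the uncertainty is wider than these three steps alone suggest. The estimated step is a 1.4-fold higher number from compound 3 to compound 4 (0.15 log units; within the scatter). For compound 4 the expected value is 0.7 mg/kg, with an estimated range of 0.25 mg/kg to 2.5 mg/kg.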

Compound 4, dose for 50% inhibition: > 5 mg/kg
Compound 4 ended at the assay's limit (the forecaster's own chance of this, stated with the estimate: 8%); middle value at least 7.1-fold (0.85 log units) away from the limit.
By their numbers in this assay, from the lowest: compounds 1, 2 and 3 (each within the scatter of the next). At a limit, above all of these: compound 4.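

In this assay the position proves less forgiving than the three chains on the oxygen suggested: ethylsulfanyl in place of allyloxy gives an at least 10-fold higher number from compound 3 to compound 4 (1.00 log units; beyond the scatter) and ethylsulfanyl in place of sec-butoxy gives an at least 10-fold higher number from compound 2 to compound 4 (1.00 log units; beyond the scatter) and ethylsulfanyl in place of butoxy gives an at least 10-fold higher number from compound 1 to compound 4 (1.00 log units; beyond the scatter) on the same aromatic carbon. The tolerance seen among allyloxy, butoxy and sec-butoxy therefore does not extend to this change, the only one shown that replaces the oxygen. From the compounds shown here alone, the value of compound 4 is a limit and not a number, so the full size of these steps stays unknown: the limit of > 5 mg/kg in this assay, at which 1 of the 4 values shown sits.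

The compounds shown leave open whether the sulfur or the ethyl chain accounts for the step. An ethoxy group or a butylsulfanyl group on this carbon would separate the two.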